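Swapping methoxyphenyl for difluorophenyl on the shared core

This account rests on a few compounds, and the source may have more. Where it says the series, first, only, none or still open, it means among the compounds named here.

Two compounds on the shared core carry numbers. Compound 1 `COc1ccc(C=c2s/c(=C3\C(=O)Nc4cc(F)ccc43)n(CCN(C)C)c2=O)cc1` gives 2200 nM in a functional assay on NCI-H460 cells (Homo sapiens) for inhibition, read by MTT assay, with a stated time of 72 h (on this read-out higher numbers stand for weaker inhibition and lower numbers for stronger inhibition), and stands as the higher of the two numbers; compound 2 `CN(C)CCn1c(=O)c(=Cc2ccc(O)cc2)s/c1=C1\C(=O)Nc2ccc(F)cc21` gives 1270 nM in this assay, a gap that lies within the scatter, so no order between them can be read. Compound 3 `CN(C)CCn1c(=O)c(=Cc2ccc(F)cc2F)s/c1=C1\C(=O)Nc2cc(F)ccc21` is not yet measured. It differs from compound 1 by 2,4-difluorophenyl in place of 4-methoxyphenyl on a double-bonded chain carbon bound to an aromatic carbon. Going by the values given here, no measured pair covers this change, so nothing beyond the scatter is expected in either direction. The expected step is a 1.2-fold lower number from compound 1 to compound 3 (0.06 log units; within the scatter). Compound 3 is estimated at 1900 nM, within 700 nM to 5500 nM.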

Compound 3, half-maximal inhibitory concentration: 3200 nM
Beside the measured number, compound 3's estimate is 1.7-fold (0.23 log units) below it; the measured number falls inside the stated range.
By their numbers in this assay, from the lowest: compounds 2, 1 and 3 (each within the scatter of the next, the first and the last beyond it).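

In this assay the step is a 1.5-fold higher number from compound 1 to compound 3 (0.16 log units; within the scatter), so 2,4-difluorophenyl and 4-methoxyphenyl cannot be told apart at this position on the shared core. Going by these compounds alone, this pair gives the first step at this position, and losing the methoxy oxygen while adding two fluorines leaves the number with no readable shift. No evidence on hand accounts for the result.

Open, from the compounds shown here alone, is whether a 4-aminophenyl or 4-carboxyphenyl group at this place would take the number beyond the scatter. Within the data shown here, compound 2 differs from compound 1 and compound 3 in more than one place, so it gives no step here.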